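Swapping an ester for a pentyl chain on the triazole

This account rests on a few compounds, and the source may have more. Where it says the series, first, only, none or still open, it means among the compounds named here.

Compounds with a measured value:
compound 1, `CCCCCCCc1cn(C(c2ccccc2)c2cc3cc(Br)ccc3nc2OC)nn1`, 9.7%
compound 2, `COc1nc2ccc(Br)cc2cc1C(c1ccccc1)n1cc(-c2ccccc2)nn1`, 13.9%
compound 3, `CCOC(=O)c1cn(C(c2ccccc2)c2cc3cc(Br)ccc3nc2OC)nn1`, -3.67%

These three compounds share one core and differ only in the group carried on an aromatic carbon of the triazole. In an ADME assay on HeLa cells (Homo sapiens) for cytotoxicity, read by sulforhodamine B assay, with a stated time of 48 h, tested at 10 uM (a higher number here means more inhibition at the concentration tested (going by the name of the read-out), a lower number less inhibition), compound 3 gives -3.67%, the lowest of the three numbers. Its nearest neighbour is compound 1 with 9.7%, and furthest away stands compound 2 with 13.9%. The two steps that lead to compound 3 are both beyond the scatter: a number 13.4 percentage points lower from compound 1 to compound 3 (beyond the scatter) and a number 17.6 percentage points lower from compound 2 to compound 3 (beyond the scatter). Between compound 1 and compound 2 the change is within the scatter, a number 4.2 percentage points higher from compound 1 to compound 2 (within the scatter).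

Compound 4, `CCCCCc1cn(C(c2ccccc2)c2cc3cc(Br)ccc3nc2OC)nn1`, has not been measured. The change from compound 3 to compound 4 is pentyl in place of ethoxycarbonyl on an aromatic carbon. For the measured compounds named here, the step that bears most on this is the one between compound 1 and compound 3, since heptyl and pentyl are both plain chains; read the other way round it points to a modest rise in this assay. Compound 4 is therefore expected to give 8%, with a likely range from -4% to 20%. The estimated step is a number 11.7 percentage points higher from compound 3 to compound 4 (beyond the scatter).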

Compound 4, a percentage reported as inhibition, at one concentration (the size of the read-out at that concentration, not a potency): -9.81%
Compound 4: the middle estimate sits 17.8 percentage points above what was measured; measured number outside the range, below it.
By their numbers in this assay, from the lowest: compounds 4 and 3 (each within the scatter of the next); then compounds 1 and 2 (each within the scatter of the next).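

At this aromatic carbon of the triazole, two plain chains do not read alike in this assay: cutting heptyl back to pentyl gives a number 19.5 percentage points lower from compound 1 to compound 4 (beyond the scatter), so chain length matters here even though the change lies far out on the chain. Putting pentyl in place of ethoxycarbonyl gives a number 6.1 percentage points lower from compound 3 to compound 4 (within the scatter), which means that the low end of this small set is not tied to the ester and is also reached with a chain of carbon alone. Putting pentyl in place of phenyl gives a number 23.7 percentage points lower from compound 2 to compound 4 (beyond the scatter), so the earlier agreement between heptyl and phenyl does not extend to every hydrocarbon group at this position. Nothing at hand gives a cause for these steps.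

The compounds shown leave open how the number runs with chain length, which a butyl, hexyl or octyl chain at this carbon would help to settle. They also leave open whether a carboxylic acid or an amide in place of the ester would read like compound 3 at the single concentration tested.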